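Swapping the oxadiazole isomer on a bradykinin antagonist

The source may report more compounds than this note shows. Statements on the series, on what has been measured and on what is new or still open speak of the compounds shown alone.

The series shares a core in which a chloropyridine bearing a cyanoacetamide is linked through a methyl-substituted benzylic amine to a biaryl. Compound 1 `C[C@@H](Nc1nccc(Cl)c1NC(=O)CC#N)c1ccc(-c2cccc(F)c2C#N)cc1` carries a nitrile on the fluorinated outer ring, and in a functional assay on CHO cells for antagonist activity at B1 bradykinin receptor (Homo sapiens), read by FLIPR and calcium flux (a lower number here means a stronger inhibitor, a higher number a weaker inhibitor), compound 1 has "not determined" (no result reported). Compound 2 `Cc1noc(-c2c(F)cccc2-c2ccc([C@@H](C)Nc3nccc(Cl)c3NC(=O)CC#N)cc2)n1` replaces that nitrile with a methyl oxadiazole, and in this assay compound 2 gives 0.94 nM. For the measured compounds named here, that is the only number in the set, so compound 2 stands alone as the reference point, with no measured neighbour to mark any step.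

Compound 3 `Cc1nc(-c2c(F)cccc2-c2ccc([C@@H](C)Nc3nccc(Cl)c3NC(=O)CC#N)cc2)no1` is built from the same atoms joined differently: 5-methyl-1,2,4-oxadiazol-3-yl in place of 3-methyl-1,2,4-oxadiazol-5-yl on an aromatic carbon. The ring keeps its size, its heteroatom count and its acceptor count, and only the attachment point and the position of the methyl shift within it. Going by the values given here, with no measured step of this kind available, any expectation must rest on the closeness of the two isomers alone.

The author expects the step in this assay from compound 2 to compound 3 to be small, a 1.7-fold higher number from compound 2 to compound 3 (0.23 log units; within the scatter), at most a modest loss and quite possibly nothing beyond the usual scatter. For compound 3 the estimated value is 1.6 nM, with a plausible range from 0.5 nM to 5 nM.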

Compound 3, half-maximal inhibitory concentration: 0.78 nM
Compound 3: middle estimate off by 2.1-fold (0.31 log units), on the high side, within the range that was stated.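

In this assay, for the compounds shown here, the change from 3-methyl-1,2,4-oxadiazol-5-yl to 5-methyl-1,2,4-oxadiazol-3-yl amounts to a 1.2-fold lower number from compound 2 to compound 3 (0.08 log units; within the scatter) and is the first step in the set that can be read at all. It shows that, on this aromatic carbon ortho to a fluoro group, moving the attachment point and the methyl within the ring leaves the two isomers indistinguishable in this read-out, so compound 3 now joins compound 2 as a second reference point for the position. No measurement bears on why the two isomers read alike.

Going by these compounds alone, the step covers only this one pair of isomers, and with compound 1 at "not determined" (no result reported) in this assay the nitrile offers no comparison with either oxadiazole. Open too, as far as these compounds go, is how far the position would accept other groups, such as a primary amide, a carboxylic acid or an unsubstituted 1,2,4-oxadiazole, and whether an ethyl or a cyclopropyl in place of the methyl on either isomer would hold the value as closely.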